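This account rests on a few compounds, and the source may have more. Where it says the series, first, only, none or still open, it means among the compounds named here.

Measured so far in a functional assay on MCF7 cells (Homo sapiens) for cytotoxicity, read by sulforhodamine B assay, with a stated time of 48 h (on this read-out lower numbers stand for stronger inhibition and higher numbers for weaker inhibition), for this series
- compound 1 `O=C(/C=C/c1ccc(Br)cc1)c1cccc(-c2cccc(F)c2)c1` gives 18300 nM
- compound 2 `O=C(/C=C/c1cccc(Br)c1)c1cccc(-c2cccc(F)c2)c1` gives 12700 nM
- compound 3 `COc1ccc(/C=C/C(=O)c2cccc(-c3cccc(F)c3)c2)cc1` gives 3080 nM

Compound 3 (3080 nM) holds the lowest of the three numbers. Compound 4 `O=C(/C=C/c1ccc(Cl)cc1)c1cccc(-c2cccc(F)c2)c1` carries chloro in place of methoxy on an aromatic carbon, para to a large group (chloro in place of methoxy on an aromatic carbon). Among the compounds with values here, the closest precedent is the swap at that same place, a 5.9-fold lower number from compound 1 to compound 3 (0.77 log units; beyond the scatter), here read in reverse. The step of a 4.1-fold lower number from compound 2 to compound 3 (0.62 log units; beyond the scatter) also bears on it, though the bromo sits elsewhere there. Moving the bromo gave a 1.4-fold lower number from compound 1 to compound 2 (0.16 log units; within the scatter) as the only other step. Within the data shown here, no chloro compound has been measured, so the bromo precedent is only a proxy. In this assay a modest rise is expected, the estimated step being a 3.9-fold higher number from compound 3 to compound 4 (0.59 log units; beyond the scatter) overall. The estimate for compound 4 is 12000 nM, with an expected range from 5000 nM to 25000 nM in this read-out.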

Compound 4, half-maximal inhibitory concentration: 18200 nM
Estimate against measurement, compound 4: 1.5-fold (0.18 log units) below; the measured number falls inside the stated range.
By their numbers in this assay, from the lowest: compound 3; then compounds 2, 4 and 1 (each within the scatter of the next).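

In this assay, chloro on this aromatic carbon, para to a large group, reads like bromo (a 1.0-fold lower number from compound 1 to compound 4 (0.00 log units; within the scatter)) and not like methoxy (a 5.9-fold higher number from compound 3 to compound 4 (0.77 log units; beyond the scatter)), so the earlier bromo proxy now has a direct chloro counterpart. Within the data shown here, the 4-chlorophenyl group also cannot be told apart from 3-bromophenyl (a 1.4-fold higher number from compound 2 to compound 4 (0.16 log units; within the scatter)), which leaves compound 3 as the only compound standing apart from the others. Nothing measured here accounts for the gap between methoxy and the halogens. The compounds shown leave open whether ethoxy, hydroxyl or dimethylamino at this place would read like methoxy or like the halogens.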